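A few compounds are considered here, and "the series" means these few. Any claim that something is new, unique, unknown or untested is made for them only; others in the source may bear on it.

Compound 1, with the structure `COC(=O)[C@@H]1COC(/C=C/c2ccc(F)cc2)=N1`, is the starting point. In an ADME assay on Vero cells (Chlorocebus sabaeus) for cytotoxicity, read by WST assay, tested at 50 ug/mL (on this read-out higher numbers stand for a weaker effect at the one concentration tested and lower numbers for a stronger effect), compound 1 gives 91.6%. Compound 2, with the structure `COC(=O)[C@@H]1COC(/C=C/c2ccc(OC)cc2)=N1`, differs from it by a single change, (methoxy in place of fluoro on an aromatic carbon), and in this assay compound 2 gives 94.8%. The step between them, a number 3.2 percentage points higher from compound 1 to compound 2 (within the scatter), is small enough to sit inside the usual run-to-run variation of such a measurement, so the two values cannot be told apart.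

Compound 3, with the structure `COC(=O)c1coc(/C=C/c2ccc(F)cc2)n1`, carries a different core; the difference between the core of compound 1 and the core of compound 3 is not broken down here. In this assay compound 3 gives 102%.

Compound 4, with the structure `COC(=O)c1coc(/C=C/c2ccc(OC)cc2)n1`, has not been measured. It is related to compound 3 by the same change that relates compound 2 to compound 1: methoxy in place of fluoro on an aromatic carbon. The step of a number 2 percentage points lower from compound 3 to compound 4 (within the scatter) is expected to be small, because a number 3.2 percentage points higher from compound 1 to compound 2 (within the scatter) stayed within the scatter. For compound 4 the expected value is therefore 100%, with a likely range from 88% to 110%.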

Compound 4, a percentage reported as activity, at one concentration (the size of the read-out at that concentration, not a potency): 99.6%
The estimate for compound 4 lay 0.4 percentage points above the measured number; the measured number falls inside the stated range.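

Putting methoxy in place of fluoro on the aromatic ring also makes no clear difference on the second core in this assay, where the reading is a number 2.4 percentage points lower from compound 3 to compound 4 (within the scatter). Set beside the earlier step, the same change behaves alike on both cores, as far as this read-out can tell: the same change on two cores in this assay, a number 3.2 percentage points higher (within the scatter) from compound 1 to compound 2 and a number 2.4 percentage points lower (within the scatter) from compound 3 to compound 4, 5.6 percentage points apart, within the scatter of two such steps. This supports carrying the change between these two cores without expecting a clear shift in this assay, but it rests on just two pairs of compounds at a single concentration, and it shows neither that the result would hold on another core nor whether a small real effect lies hidden in the scatter.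

The compounds shown carry only fluoro or methoxy on the aromatic ring, and all of them keep the methyl ester. Whether an amine on that ring or a carboxylic acid in place of the ester would read the same in this assay remains open, as does the behaviour of any of these compounds at other concentrations.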